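From an Aromatic Ester to a Phenol on One Amide Core

The source may report more compounds than this note shows. Statements on the series, on what has been measured and on what is new or still open speak of the compounds shown alone.

Measured so far in an assay on isolated protein for inhibition of Apoptosis regulator Bcl-2 (Homo sapiens), read by fluorescence polarization, with stated times of 5 min and 10 min; on this read-out higher numbers stand for weaker inhibition and lower numbers for stronger inhibition:
compound 1 `CC(C)=CCCC1=CC[C@H](C(=O)N(C)O)[C@@H](c2ccccc2)C1` gives 2100 nM.
compound 2 `COC(=O)c1ccc(NC(=O)[C@H]2CC=C(CCC=C(C)C)C[C@@H]2c2ccccc2)cc1` gives > 23000 nM.
compound 3 `COC(=O)CCNC(=O)[C@@H]1CC=C(CCC=C(C)C)C[C@H]1c1ccccc1` gives > 23000 nM.

All three share the same core, a cyclohexene ring carrying a phenyl group and a side chain, and differ only in the amide part. Going by the values given here, compound 1, with a hydroxamic amide, is the one compound for which this assay returns a number. For compound 2 the figure is not a number but a limit of the assay. For compound 3 the figure is likewise a limit. Compound 2 therefore stands with compound 3 at the limit of > 23000 nM in this assay, at which 2 of the 3 values shown sit, and nothing among the numbers separates the two.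

Compound 4 `CC(C)=CCCC1=CC[C@H](C(=O)Nc2ccc(O)cc2)[C@@H](c2ccccc2)C1` is the next anilide. It differs from compound 2 by hydroxy in place of methoxycarbonyl on an aromatic carbon. Among the compounds with values here, no measured pair tracks this change, so no step size can be read from the data. Both aromatic amide and aliphatic amide so far sit at the limit, and the change is confined to the para group of the anilide. The expectation is that compound 4 stays in the same weak region, with the step from compound 2 expected to be an at least 1.1-fold lower number from compound 2 to compound 4 (0.06 log units; that floor lies within the scatter), no larger than the usual scatter. Compound 4 is thus estimated at 20000 nM, between 5000 nM and 60000 nM.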

Compound 4, inhibition constant: > 23000 nM
Compound 4 gave a limit, no number; the forecaster's own chance of this, stated with the estimate: 55%; middle value at least 1.1-fold (0.06 log units) away from the limit.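

In this assay compound 4 gives > 23000 nM, which is a limit and not a number. Going by these compounds alone, putting (4-hydroxyphenyl)amino in place of hydroxy(methyl)amino on the carbonyl carbon gives an at least 10-fold higher number from compound 1 to compound 4 (1.03 log units; beyond the scatter), the first readable step at this amide position, and it shows that an anilide carrying a hydroxy group does not recover the measurable value of the hydroxamic amide on the same core. The step for hydroxy in place of methoxycarbonyl cannot be read, as both of its ends are limits, so swapping the 4-(methoxycarbonyl)phenyl group for 4-hydroxyphenyl brings no number back, and the hydroxamic amide remains the only amide part here with a measured value: the limit of > 23000 nM in this assay, at which 3 of the 4 values shown sit.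

On these data alone, whether a carboxylic acid or an amine on the aromatic carbon of the anilide would give a number stays open, as does the true distance between compound 2 and compound 4. Also open, as far as these compounds go, is which part of the hydroxy(methyl)amino group of compound 1 matters, a question that a plain methylamino or hydroxyamino group on the same carbonyl carbon could help to settle.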